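A few compounds are considered here, and "the series" means these few. Any claim that something is new, unique, unknown or untested is made for them only; others in the source may bear on it.

Compound 1 `COc1cc2ncnc(Nc3cccc(Cl)c3)c2cc1OCCCCC(=O)Nc1ccc(S(N)(=O)=O)cc1` and compound 2 `COc1cc2ncnc(Nc3ccc(OCc4cccc(F)c4)c(Cl)c3)c2cc1OCCCCC(=O)Nc1ccc(S(N)(=O)=O)cc1` differ in one place: (3-fluorobenzyl)oxy in place of hydrogen on an aromatic carbon. In a functional assay on A549 cells (Homo sapiens) for antiproliferative activity, read by MTT assay, with a stated time of 72 h (a lower number here means a stronger inhibitor, a higher number a weaker inhibitor), compound 1 gives 11200 nM. In this assay compound 2 gives 7860 nM, so that a 1.4-fold lower number from compound 1 to compound 2 (0.15 log units; within the scatter). Compound 3 `NS(=O)(=O)c1ccc(NC(=S)Nc2ccc3ncnc(Nc4cccc(Cl)c4)c3c2)cc1` is built on a different core; the difference between the two cores is not broken down here. In this assay compound 3 gives > 40000 nM, which is a limit of the assay and not a number, (the limit of > 40000 nM in this assay, at which 1 of the 3 values shown sits). Compound 4 `NS(=O)(=O)c1ccc(NC(=S)Nc2ccc3ncnc(Nc4ccc(OCc5cccc(F)c5)c(Cl)c4)c3c2)cc1` is compound 3 with the same change: (3-fluorobenzyl)oxy in place of hydrogen on an aromatic carbon. Because in the measured pair a 1.4-fold lower number from compound 1 to compound 2 (0.15 log units; within the scatter), the expected step here is likewise small, a number no higher from compound 3 to compound 4 (the limit leaves the size open). Compound 4 is therefore estimated at 40000 nM, between 20000 nM and 80000 nM, most likely again reported only as a limit.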

Compound 4, half-maximal inhibitory concentration: > 40000 nM
Compound 4: only a limit was reported (the forecaster's own chance of this, stated with the estimate: 70%); the middle value lies on the limit itself.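

In this assay, compound 3 and compound 4 are each reported only as a limit of the assay, so no step can be read between them: the limit of > 40000 nM in this assay, at which 2 of the 4 values shown sit. On these data alone, how far adding (3-fluorobenzyl)oxy moves the number on the core of compound 3 stays open.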